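From bromo to trifluoromethyl on the shared core

The source may report more compounds than this note shows. Statements on the series, on what has been measured and on what is new or still open speak of the compounds shown alone.

Of the compounds shown here, two have been measured in an assay on brain for binding affinity to Neuronal acetylcholine receptor; alpha4/beta2 (Rattus norvegicus), read by radioligand binding; a lower number here means a stronger inhibitor, a higher number a weaker inhibitor. Compound 1 `Clc1cncc(OC[C@@H]2CCN2)c1` gives 0.042 nM. Among the compounds with values here, compound 2 `Brc1cncc(OC[C@@H]2CCN2)c1` gives 0.18 nM, the higher of the two numbers; its only neighbour is compound 1, and the single measured step is a 4.3-fold higher number from compound 1 to compound 2 (0.63 log units; beyond the scatter), a modest weakening that lies beyond the scatter.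

Compound 3 `FC(F)(F)c1cncc(OC[C@@H]2CCN2)c1` is the next member: trifluoromethyl in place of bromo on an aromatic carbon. Within the data shown here, no measured step covers a trifluoromethyl at this position, so the only guide is a 4.3-fold higher number from compound 1 to compound 2 (0.63 log units; beyond the scatter), which went up when the larger halogen replaced the smaller one. Since the trifluoromethyl group brings four heavy atoms where bromo brought one, the expectation for compound 3 is a further rise in this assay of about the same order as that step, or somewhat larger, with the direction toward a weaker inhibitor: a 5.6-fold higher number from compound 2 to compound 3 (0.74 log units; beyond the scatter) is the step expected from compound 2. Compound 3 is therefore estimated at 1 nM in this assay, with a plausible range from 0.2 nM to 5 nM; a result within the scatter of compound 2 cannot be excluded on two data points.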

Compound 3, inhibition constant: 0.49 nM
Compound 3: the middle estimate sits 2.0-fold (0.31 log units) above what was measured; low and high end bracket the measured number.
By their numbers in this assay, from the lowest: compound 1; then compound 2; then compound 3.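

The aromatic carbon that carried the halogens also accepts a group that is not a halogen: in this assay, trifluoromethyl, with 4 heavy atoms against 1 for bromo, gives a 2.7-fold higher number from compound 2 to compound 3 (0.43 log units; beyond the scatter) and the change stays modest despite the larger group. Set against chloro, the same group gives a 12-fold higher number from compound 1 to compound 3 (1.07 log units; beyond the scatter) and this large step is the widest seen at this position, so the series now runs from chloro through bromo to trifluoromethyl, with each step beyond the scatter and compound 1 holding the lowest number of the three. No evidence is available to explain this order or to separate the contribution of size from any other difference between the groups.

Going by these compounds, with only these three groups, it remains open whether a fluoro, a methyl or a nitrile on the same carbon would fit this order. An amine or a carboxylic acid there, each bringing hydrogen-bond donors or acceptors that the three groups shown lack, would test the position in a way that this series cannot.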